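Moving a hydroxylated amide onto a second core

The source may hold more compounds than are shown below. What is called first, only, known or untested is meant among the compounds shown, and "the series" means these compounds.

Two pairs of compounds share one structural change. Compound 1 `COc1c(F)ccc2c1c(NS(=O)(=O)c1ccc(Cl)s1)nn2Cc1cccc(CNC(C)=O)c1` and compound 2 `COc1c(F)ccc2c1c(NS(=O)(=O)c1ccc(Cl)s1)nn2Cc1cccc(CNC(=O)C(C)(C)O)c1` differ in that compound 2 carries 1-hydroxy-1-methylethyl in place of methyl on a carbonyl carbon. In an assay on isolated protein (blood) for antagonist activity at C-C chemokine receptor type 4 (Homo sapiens), read by flow cytometry, with a stated time of 30 min (a lower number here means tighter binding, a higher number weaker binding), compound 1 gives 3160 nM, and compound 2 gives 631 nM; this is the step of a 5.0-fold lower number from compound 1 to compound 2 (0.70 log units; beyond the scatter).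

Compound 3 `COc1cc(F)cc2c1c(NS(=O)(=O)c1ccc(Cl)s1)nn2Cc1cccc(CNC(C)=O)c1` has a core built from the same atoms as compound 1 but joined differently; the difference between the two cores is not broken down here. In this assay compound 3 gives 1000 nM. Compound 4 `COc1cc(F)cc2c1c(NS(=O)(=O)c1ccc(Cl)s1)nn2Cc1cccc(CNC(=O)C(C)(C)O)c1` is the unmeasured partner of compound 3 and carries 1-hydroxy-1-methylethyl in place of methyl on a carbonyl carbon, the same change made from compound 1 to compound 2.

Because the change is the same and the step of a 5.0-fold lower number from compound 1 to compound 2 (0.70 log units; beyond the scatter) stands beyond the usual scatter, compound 4 is expected to land at a lower number than compound 3, with a step of about a 4.0-fold lower number from compound 3 to compound 4 (0.60 log units; beyond the scatter). The expectation rests on one measured pair only, so a somewhat smaller gain would not surprise. The estimated value for compound 4 in this assay is 250 nM, likely between 100 nM and 630 nM.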

Compound 4, dissociation constant in the C-C chemokine receptor type 4 assay: 631 nM
The estimate for compound 4 lay 2.5-fold (0.40 log units) below the measured number; the measured number lies above the stated range.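

In the C-C chemokine receptor type 4 assay, compound 3 gives 1000 nM and compound 4 gives 631 nM; the change on the second core gives a 1.6-fold lower number from compound 3 to compound 4 (0.20 log units; within the scatter), so the clear gain seen on the core of compound 1 does not reappear by a margin that can be told from scatter. Set side by side, the two steps differ: the same change on two cores in the C-C chemokine receptor type 4 assay, a 5.0-fold lower number (0.70 log units; beyond the scatter) from compound 1 to compound 2 and a 1.6-fold lower number (0.20 log units; within the scatter) from compound 3 to compound 4, 3.2-fold (0.50 log units) apart, beyond the scatter of two such steps. Within the data shown here, this shows that a step measured on one core cannot simply be carried over to the other, yet with only two pairs it does not show which feature of the cores is responsible, or which step would be the more typical on a further core.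

The compounds shown leave open whether another group on that carbonyl carbon, such as a longer chain ending in a hydroxyl or a chain carrying an amine, would also give different steps on the two cores. On these data alone, in a physicochemical assay for lipophilicity (on this read-out higher numbers stand for higher lipophilicity and lower numbers for lower lipophilicity), compound 3 gives 4.1 and compound 4 gives 4.2; the change gives a number 0.10 log units higher from compound 3 to compound 4 (within the scatter), and how it reads on the core of compound 1 stays open.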